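The source may report more compounds than this note shows. Statements on the series, on what has been measured and on what is new or still open speak of the compounds shown alone.

In an ADME assay on HMVE cells (Homo sapiens) for inhibition, read by resazurin assay, with a stated time of 72 h (a higher number here means a weaker inhibitor, a lower number a stronger inhibitor), compound 1 `O=C(O)c1ccc2cc(-c3ccc(O)c([C@@H]4CC[C@@H]5CCCC[C@H]5C4)c3)ccc2c1` gives > 500 nM, which is a limit of the assay rather than a number, as the limit of > 500 nM in this assay, at which 1 of the 2 values shown sits, notes. Compound 2 `O=C(O)c1ccc2cc(-c3ccc(O)c([C@H]4CCC5CCCC[C@H]5C4)c3)ccc2c1` differs from compound 1 only in the cyclohexyl-bearing ring system, where the fact that one of compounds 1 and 2 is drawn with a defined configuration and the other without, at the place where they differ applies; in this assay compound 2 has "not determined" (no result reported), so it stands on no number at all. Compound 3 `O=C(O)c1ccc2cc(-c3ccc(O)c([C@@H]4CCC[C@H]5CCCCC54)c3)ccc2c1` is the pair to compound 2 with a different joining of the same atoms: a group of 10 heavy atoms (10 carbon; 2 six-membered non-aromatic rings of carbon only) in place of a group of 10 heavy atoms (10 carbon; 2 six-membered non-aromatic rings of carbon only), on an aromatic carbon. No step between measured compounds is shown, and compound 2 gives no number, so no size of step from compound 2 to compound 3 in this assay can be expected in either direction; the single limit for compound 1 is the only anchor. Compound 3 is therefore expected to sit near that limit, with an estimated value of 1500 nM, somewhere between 300 nM and 10000 nM.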

Compound 3, half-maximal inhibitory concentration: > 500 nM
Compound 3: only a limit was reported; the forecaster's own chance of this, stated with the estimate: 60%; the middle value lies beyond the limit too.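

No step from compound 1 to compound 3 can be read in this assay, since each gives only a limit of the assay and not a number: the limit of > 500 nM in this assay, at which 2 of the 3 values shown sit.

The compounds shown leave open whether the different joining of the ring atoms changes inhibition at all, and where compound 2 stands.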